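Methyl for methoxy on two differently joined cores

The compounds below may be only part of what the source reports. "The series", "measured", "known", "first", "only" and "open" are said of these compounds alone.

Two cores are in play. Compound 1 `COc1ccc2[nH]c3c4cn[nH]c4c4c(c3c2c1)C(=O)NC4=O` and compound 2 `Cc1ccc2[nH]c3c4cn[nH]c4c4c(c3c2c1)C(=O)NC4=O` share one core; compound 3 `COc1ccc2[nH]c3c(c4c(c5ccnn53)C(=O)NC4=O)c2c1` and compound 4 `Cc1ccc2[nH]c3c(c4c(c5ccnn53)C(=O)NC4=O)c2c1` share another. Compound 3 is built from the same atoms as compound 1, joined differently, and the difference between the two cores is not broken down here.

In a functional assay on U-373MG ATCC cells (Homo sapiens) for cytotoxicity, read by MTT assay, with a stated time of 72 h (on this read-out lower numbers stand for stronger inhibition and higher numbers for weaker inhibition), compound 1 gives 51000 nM. For compound 2 the read-out in this assay is a limit of the assay, > 100000 nM. For compound 3 the read-out in this assay is also a limit of the assay, > 100000 nM.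

The change from compound 1 to compound 2 is methyl in place of methoxy on an aromatic carbon. The step it made, an at least 1.9-fold higher number from compound 1 to compound 2 (0.29 log units; that floor lies within the scatter), runs into (the limit of > 100000 nM in this assay, at which 2 of the 3 values shown sit), so its full size is not known. The change from compound 3 to compound 4 is the same: methyl in place of methoxy on an aromatic carbon.

Compound 3 is already at the limit of this assay, and nothing in the measured pair argues that the methyl would bring the number down. A step that the limit leaves unreadable from compound 3 to compound 4 is expected, which in practice means the read-out for compound 4 is expected to stay at the limit because the read-out of compound 3 is > 100000 nM and because the same change gave an at least 1.9-fold higher number from compound 1 to compound 2 (0.29 log units; that floor lies within the scatter) on the other core. Compound 4 is estimated at 150000 nM, with a range from 60000 nM to 400000 nM in this assay.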

Compound 4, half-maximal inhibitory concentration: 57000 nM
Estimate against measurement, compound 4: 2.6-fold (0.42 log units) above; measured number outside the range, below it.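

In this assay the change of methoxy to methyl on an aromatic carbon gives an at least 1.7-fold lower number from compound 3 to compound 4 (0.24 log units; that floor lies within the scatter) and so does not carry over in direction from one core to the other, even though the change itself is the same on both: the same change on two cores in this assay, an at least 1.9-fold higher number (0.29 log units; that floor lies within the scatter) from compound 1 to compound 2 and an at least 1.7-fold lower number (0.24 log units; that floor lies within the scatter) from compound 3 to compound 4, at least 3.4-fold (0.53 log units) apart, beyond the scatter of two such steps

The full size of neither step can be read, because each has one end at a limit of the assay: the limit of > 100000 nM in this assay, at which 2 of the 4 values shown sit.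

The result therefore fixes the opposite directions of the two steps but neither their sizes nor which part of the difference between the cores goes with the split, and it supports no rule beyond compound 1, compound 2, compound 3 and compound 4.

At this place on the ring the compounds shown carry only methoxy or methyl, so it stays open how an amine, a carboxylic acid, a hydroxyl or a longer chain such as ethoxy would read out on either core. Also open, as far as these compounds go, is whether the split between the cores would persist for such groups, or whether any of them would bring either core clear of the limit and give a step of readable size.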